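Methyl on the triple bond of compound 3

This account rests on a few compounds, and the source may have more. Where it says the series, first, only, none or still open, it means among the compounds named here.

Measured so far in a physicochemical assay for pharmacokinetics, read by LC-MS, in phosphate buffer, tested at 1 uM; on this read-out lower numbers stand for a shorter-lived compound and higher numbers for a longer-lived compound:
- compound 1 `Cc1cc2c(C(=O)NCC#N)cccc2n1-c1nc2c(c(NCc3ccccc3)n1)CCCC2`: > 24 h
- compound 2 `CC#CCNC(=O)c1cccc2c1cc(C)n2-c1nc2c(c(NCc3ccccc3)n1)CCCC2`: > 24 h
- compound 3 `C#CCNC(=O)c1cccc2c1cc(C)n2-c1nc2c(c(NCc3ccccc3)n1)COCC2`: > 24 h

Each of these readings is a limit of the assay and not a number. For the measured compounds named here, the series so far shows (the limit of > 24 h in this assay, at which 3 of the 3 values shown sit). Compound 3 therefore stands at > 24 h, which is a limit.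

Compound 4 `CC#CCNC(=O)c1cccc2c1cc(C)n2-c1nc2c(c(NCc3ccccc3)n1)COCC2` differs from compound 3 by one change: methyl in place of hydrogen on a triple-bonded carbon. In words, this is methyl in place of hydrogen on a triple-bonded carbon, or propargyl to but-2-yn-1-yl.

Going by the values given here, the one measured step that bears on it also brings in prop-1-yn-1-yl: a step that the two limits leave unreadable from compound 1 to compound 2. Given that step of unreadable size, a step that the two limits leave unreadable from compound 1 to compound 2, no step beyond the scatter is expected in this assay, and no direction can be assigned. The estimated change is a step that the limit leaves unreadable from compound 3 to compound 4. Compound 4 is expected at 30 h, with an estimated range of 24 h to 48 h, and the assay will probably report only a limit again.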

Compound 4, half-life: > 24 h
Compound 4 ended at the assay's limit; the forecaster's own chance of this, stated with the estimate: 90%; the middle value lies beyond the limit too.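

No step can be read from compound 3 to compound 4 in this assay, because both readings are limits of the assay: the limit of > 24 h in this assay, at which 4 of the 4 values shown sit.

The compounds shown leave open how long any of them actually lasts, and whether methyl in place of hydrogen on a triple-bonded carbon changes the half-life at all.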